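Swapping Methoxy for Dimethylamino on Compound 2

The source may report more compounds than this note shows. Statements on the series, on what has been measured and on what is new or still open speak of the compounds shown alone.

Among the measured compounds shown here, in an ADME assay on HeLa cells (Homo sapiens) for cytotoxicity, read by MTT assay, with a stated time of 2 days (a higher number here means that more compound is tolerated, a lower number that less compound is tolerated), compound 2 `CNC(=O)c1cc(Oc2ccc3c(C)c(C(=O)OC)sc3c2)ccn1` gives 15700 nM, the lower of the two exact numbers so far. Its nearest neighbour is compound 3 `CCCOC(=O)c1sc2cc(Oc3ccnc(C(=O)NC)c3)ccc2c1C` at 57100 nM. Compound 1 `CCOC(=O)c1cc2ccc(Oc3ccnc(C(=O)NC)c3)cc2s1` reads > 100000 nM, which is a limit of the assay and not a number.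

The next compound to be tested is compound 4 `CNC(=O)c1cc(Oc2ccc3c(C)c(C(=O)N(C)C)sc3c2)ccn1`, which has dimethylamino in place of methoxy on a carbonyl carbon.

For the measured compounds named here, only one measured step bears on this change: a 3.6-fold higher number from compound 2 to compound 3 (0.56 log units; beyond the scatter). Going by the values given here, that step alters the same methoxy group of compound 2 but keeps its oxygen, so it is only a loose guide, and no measured compound carries dimethylamino. It does suggest a modest move towards more compound being tolerated in this assay. The expected step is a 1.9-fold higher number from compound 2 to compound 4 (0.28 log units; within the scatter). For compound 4 the estimated value is 30000 nM, with an expected range from 10000 nM to 100000 nM.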

Compound 4, half-maximal cytotoxic concentration: 44400 nM
Compound 4: middle estimate off by 1.5-fold (0.17 log units), on the low side; measured number inside the range.
By their numbers in this assay, from the lowest: compound 2; then compounds 4 and 3 (each within the scatter of the next). At a limit, above all of these: compound 1.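

In this assay the move from methoxycarbonyl to dimethylcarbamoyl gives a 2.8-fold higher number from compound 2 to compound 4 (0.45 log units; beyond the scatter) and so shows that the number at this carbonyl carbon can shift even when the oxygen of the methoxy group is lost, which the ester pair alone could not show. Dimethylamino and propoxy cannot be told apart here, with a 1.3-fold lower number from compound 3 to compound 4 (0.11 log units; within the scatter), so in these compounds both replacements of methoxy read higher than compound 2 whether or not the group on the carbonyl carbon is joined through oxygen. Nothing measured here explains why either replacement moves the number.

As far as these compounds go, what a carboxylic acid or a morpholine amide would read on this carbonyl carbon stays open. So does whether an ester with a chain longer than propoxy would read higher still.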